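Moving the Branch on a Butyl Chain

A few compounds are considered here, and "the series" means these few. Any claim that something is new, unique, unknown or untested is made for them only; others in the source may bear on it.

In a functional assay on the whole organism for inhibition, with Scenedesmus acutus as the target (a lower number here means a stronger inhibitor, a higher number a weaker inhibitor), compound 1 `COC(=O)c1cc(N2C(=O)C3=C(CCCC3)C2=O)ccc1Cl` gives 1780 nM and compound 2 `CC(C)COC(=O)c1cc(N2C(=O)C3=C(CCCC3)C2=O)ccc1Cl` gives 977 nM, so these two stand within the scatter of each other. Compound 3 `CC(C)(C)OC(=O)c1cc(N2C(=O)C3=C(CCCC3)C2=O)ccc1Cl` keeps the shared core but has tert-butyl in place of isobutyl on an oxygen next to a carbonyl group. Within the data shown here, the one measured step on this chain is a 1.8-fold lower number from compound 1 to compound 2 (0.26 log units; within the scatter), which is small. On that evidence, no change beyond the scatter is expected in this assay, and no direction can be favoured. The estimated change is a 1.1-fold higher number from compound 2 to compound 3 (0.05 log units; within the scatter). Compound 3 is expected at 1100 nM, within an estimated range of 400 nM to 3000 nM.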

Compound 3, half-maximal inhibitory concentration: 81300 nM
The estimate for compound 3 lay 74-fold (1.87 log units) below the measured number, outside the stated range (above it).
By their numbers in this assay, from the lowest: compounds 2 and 1 (each within the scatter of the next); then compound 3.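

At this oxygen next to a carbonyl group, the same atoms joined differently matter greatly: in this assay tert-butyl in place of isobutyl gives an 83-fold higher number from compound 2 to compound 3 (1.92 log units; beyond the scatter), a large weakening. Tert-butyl in place of methyl gives a 46-fold higher number from compound 1 to compound 3 (1.66 log units; beyond the scatter), so tert-butyl alone stands apart here, while methyl and isobutyl remain within the scatter of each other. Nothing available explains this sharp sensitivity to the shape of the group. Still open, as far as these compounds go, is how the number responds to intermediate shapes at this oxygen. An isopropyl group or a straight butyl chain there would show whether the sharp loss is confined to tert-butyl.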